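The compounds below may be only part of what the source reports. "The series", "measured", "known", "first", "only" and "open" are said of these compounds alone.

Compound 1 `NC(=O)c1c(NC(=O)c2ccccc2Cl)sc2c1CCN(Cc1ccc(Cl)cc1)C2`: in a functional assay on HeLa cells (Homo sapiens) for antiproliferative activity, with a stated time of 24 h (on this read-out higher numbers stand for weaker inhibition and lower numbers for stronger inhibition), compound 1 gives only the assay limit > 50000 nM.
Compound 2 `NC(=O)c1c(NC(=O)c2ccccc2Cl)sc2c1CCN(C(=S)Nc1ccccc1-c1ccccc1)C2`: compound 2 gives 24000 nM.
Compound 3 `NC(=O)c1c(NC(=O)c2ccccc2Cl)sc2c1CCN(C(=S)Nc1ccc(C(F)(F)F)cc1)C2`: compound 3 gives only the limit > 50000 nM.

Compound 1 therefore stands at the limit, with no measured number of its own; (the limit of > 50000 nM in this assay, at which 2 of the 3 values shown sit). The step to compound 4 `NC(=O)c1c(NC(=O)c2ccccc2Cl)sc2c1CCN(C(=S)Nc1cccnc1)C2` is a group of 9 heavy atoms (6 carbon, 2 nitrogen, 1 sulfur; one six-membered aromatic ring with 1 hetero atom) in place of a group of 8 heavy atoms (7 carbon, 1 chlorine; one six-membered aromatic ring of carbon only), on an amine nitrogen in a ring. Within the data shown here, no measured step makes this same change. Among the measured compounds shown here, the one measured step, an at least 2.0-fold higher number from compound 2 to compound 3 (0.31 log units; beyond the scatter), shows that compounds bearing a group with one sulfur and a double bond outside aromatic rings on the amine nitrogen in a ring range from a weak number to the limit. Compound 4 bears such a group, so a weak value is expected, an at least 1.2-fold lower number from compound 1 to compound 4 (0.09 log units; that floor lies within the scatter), quite possibly the limit again. Compound 4 is estimated at 40000 nM, between 15000 nM and 100000 nM.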

Compound 4, half-maximal inhibitory concentration: > 50000 nM
Compound 4: only a limit was reported; the forecaster's own chance of this, stated with the estimate: 60%; middle value at least 1.2-fold (0.09 log units) from the limit.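

In this assay, pyridin-3-yl in place of 2-phenylphenyl on the amide-type nitrogen gives an at least 2.0-fold higher number from compound 2 to compound 4 (0.31 log units; beyond the scatter), so a second replacement of 2-phenylphenyl also weakens the read-out. Compound 4 gives only a limit, > 50000 nM, so its steps from compound 1 and compound 3 cannot be read. Only compound 2 gives a measured number, and the rest sit at the assay limit: the limit of > 50000 nM in this assay, at which 3 of the 4 values shown sit.

From the compounds shown here alone, it remains open whether plain phenyl on that nitrogen would keep the number of compound 2. Going by these compounds, it also remains open whether a pyridine ring carrying an amine or a carboxylic acid would give a measurable number.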